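The compounds below may be only part of what the source reports. "The series", "measured", "known", "first", "only" and "open" are said of these compounds alone.

Compound 1 `CCn1cc(-c2ccc(OC)cc2)c(=O)c2cc(F)c(N3CCNCC3)cc21` gives 69000 nM in a functional assay on HeLa cells (Homo sapiens) for antiproliferative activity, read by MTT assay, with a stated time of 48 h; a lower number here means a stronger inhibitor, a higher number a weaker inhibitor.
Compound 2 `CCn1cc(-c2cccc(F)c2)c(=O)c2cc(F)c(N3CCNCC3)cc21` gives 22000 nM.
Compound 3 `COc1ccc(-c2cn(C3CC3)c3cc(N4CCNCC4)c(F)cc3c2=O)cc1` gives 16500 nM.

Two single changes connect these three. Replacing the group on the aromatic carbon, (3-fluorophenyl in place of 4-methoxyphenyl on an aromatic carbon), made a 3.1-fold lower number from compound 1 to compound 2 (0.50 log units; beyond the scatter). The two cores differ by cyclopropyl in place of ethyl on an aromatic nitrogen, a change that by itself made a 4.2-fold lower number from compound 1 to compound 3 (0.62 log units; beyond the scatter). Compound 2 and compound 3 give numbers within the usual scatter of each other.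

Compound 4 `O=c1c(-c2cccc(F)c2)cn(C2CC2)c2cc(N3CCNCC3)c(F)cc12` is not yet measured. It differs from compound 3 by 3-fluorophenyl in place of 4-methoxyphenyl on an aromatic carbon. Within the data shown here, this is the same kind of change as the one from compound 1 to compound 2, though the surroundings differ: in compound 3 the carbon is meta to a cyclopropyl group (3 heavy atoms), whereas in compound 1 it is meta to an ethyl group (2 heavy atoms). Compound 4 is expected to move by a 2.8-fold lower number from compound 3 to compound 4 (0.44 log units; beyond the scatter), resting on compound 1 and compound 2, because a 3.1-fold lower number from compound 1 to compound 2 (0.50 log units; beyond the scatter) lies beyond the scatter. Compound 4 is therefore estimated at 6000 nM, with a likely range from 2500 nM to 15000 nM.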

Compound 4, half-maximal inhibitory concentration in the HeLa assay: 9160 nM
Estimate against measurement, compound 4: 1.5-fold (0.18 log units) below; the range from low to high includes it.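

In the HeLa assay, the swap of 4-methoxyphenyl for 3-fluorophenyl now reads a 1.8-fold lower number from compound 3 to compound 4 (0.26 log units; within the scatter), and it agrees with the same swap on the other core: the same change on two cores in the HeLa assay, a 3.1-fold lower number (0.50 log units; beyond the scatter) from compound 1 to compound 2 and a 1.8-fold lower number (0.26 log units; within the scatter) from compound 3 to compound 4, 1.7-fold (0.24 log units) apart, within the scatter of two such steps. The change of ethyl to cyclopropyl reads a 2.4-fold lower number from compound 2 to compound 4 (0.38 log units; beyond the scatter), and it also agrees with its earlier counterpart: the same change on two cores in the HeLa assay, a 4.2-fold lower number (0.62 log units; beyond the scatter) from compound 1 to compound 3 and a 2.4-fold lower number (0.38 log units; beyond the scatter) from compound 2 to compound 4, 1.7-fold (0.24 log units) apart, within the scatter of two such steps. Among these compounds, each change therefore carried across these two cores with a similar size, but this rests on only two pairs of steps and does not show why, or whether it would hold on any other core.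

In a physicochemical assay for solubility, at pH 7.9 (a higher number here means a more soluble compound, a lower number a less soluble compound), compound 3 gives > 400000 nM, which is a limit, not a number. In the physicochemical assay, compound 4 gives > 400000 nM, which is also a limit, not a number. The step between these two compounds cannot be read: the limit of > 400000 nM in the physicochemical assay, at which 2 of the 2 values shown sit. As far as these compounds go, it also remains open whether these step sizes would hold with a longer chain in place of the ethyl group on the aromatic nitrogen, or with a carboxylic acid on the shared core.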